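The compounds below may be only part of what the source reports. "The series", "measured", "known", "first", "only" and "open" are said of these compounds alone.

Compound 2 `O=C1C=C(c2ccc(O)cc2O[C@@H]2O[C@H](CO)[C@@H](O)[C@H](O)[C@H]2O)C(Cc2ccc(O)cc2)O1` gives 21.4 ug/mL in a physicochemical assay, with a stated time of 30 min; a higher number here means a weaker inhibitor, a lower number a stronger inhibitor. Compound 1 `COc1cc(O[C@@H]2O[C@H](CO)[C@@H](O)[C@H](O)[C@H]2O)c(O)cc1-c1coc2cc(O)ccc2c1=O` gives 20.5 ug/mL and compound 3 `COc1ccc(C2=CC(=O)OC2Cc2ccc(O)cc2)c(O[C@@H]2O[C@H](CO)[C@@H](O)[C@H](O)[C@H]2O)c1` gives 25.7 ug/mL, so compound 2 stands between them and within the scatter of both. For the measured compounds named here, the only measured step that changes an oxygen on an aromatic ring is a 1.2-fold higher number from compound 2 to compound 3 (0.08 log units; within the scatter), which stays within the scatter. Compound 4 `O=C1C=C(c2ccc(O)cc2O)C(Cc2ccc(O)cc2)O1` differs from compound 2 in one place: hydrogen in place of 3,4,5-trihydroxy-6-(hydroxymethyl)oxan-2-yl on an oxygen on an aromatic ring. Going by the values given here, no measured step removes this sugar group, so the data give no direction for it; a change no larger than the scatter is expected, meaning a 1.2-fold lower number from compound 2 to compound 4 (0.08 log units; within the scatter). The value estimated for compound 4 is 18 ug/mL, with a range from 9 ug/mL to 36 ug/mL.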

Compound 4, half-maximal inhibitory concentration: 19.5 ug/mL
For compound 4 the middle estimate is 1.1-fold (0.03 log units) below the measured one, and the stated range covers the measured number.
By their numbers in this assay, from the lowest: compounds 4, 1, 2 and 3 (each within the scatter of the next).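

In this assay, hydrogen in place of 3,4,5-trihydroxy-6-(hydroxymethyl)oxan-2-yl on this oxygen on an aromatic ring stays within the scatter (a 1.1-fold lower number from compound 2 to compound 4 (0.04 log units; within the scatter)). Compounds 1, 2 and 3 all carry this sugar group, so only compound 4 shows that the whole group can leave this position without a change beyond the scatter. No measurement here offers an explanation for this result.

Still open, on these data alone, is how this oxygen would respond to a different group, such as a carboxylic acid or an amine on a longer chain.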